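A few compounds are considered here, and "the series" means these few. Any claim that something is new, unique, unknown or untested is made for them only; others in the source may bear on it.

Compounds measured so far:
compound 1, `COc1ccc(OC)c(N2C(=O)CSC2c2cccc(C(=O)NCCCCc3ccccc3)c2)c1`: 2%
compound 2, `COc1ccccc1N1C(=O)CSC1C(=O)NCCCCc1ccccc1`: 4%
compound 3, `COc1ccc(F)cc1N1C(=O)CSC1c1cccc(C(=O)NCCCCc2ccccc2)c1`: 62%

All three were tested in a functional assay on 143B cells (Homo sapiens) for inhibition, read by CCK-8 assay, with a stated time of 72 h, tested at 1 uM; a lower number here means less inhibition, a higher number more inhibition at the concentration tested (going by the name of the read-out). Compound 3 stands highest of the three numbers; its nearest neighbour is compound 2, and compound 1 lies furthest from it, both of these gaps being beyond the scatter. Among the compounds with values here, the one step between compounds that differ in a single place is a number 60 percentage points higher from compound 1 to compound 3 (beyond the scatter), a change of fluoro in place of methoxy on an aromatic carbon, which shows how much the group on the ring nitrogen of the shared core can matter.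

Compound 4, `CCN1C(=O)CSC1c1cccc(C(=O)NCCCCc2ccccc2)c1`, has not yet been measured in this assay. It differs from compound 3 by ethyl in place of 5-fluoro-2-methoxyphenyl on an amide-type nitrogen in a ring. Within the data shown here, no measured step covers this kind of change: the only step known, from compound 1 to compound 3, exchanged one aromatic substituent for another while keeping the ring, whereas here the whole 5-fluoro-2-methoxyphenyl group leaves and an ethyl enters. Since the gain in compound 3 arrived with a number 60 percentage points higher from compound 1 to compound 3 (beyond the scatter) and that fluoro-bearing ring is now gone, a fall of a number 47 percentage points lower from compound 3 to compound 4 (beyond the scatter) is expected for compound 4. Compound 4 is therefore estimated at 15%, within 0% to 55%.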

Compound 4, a percentage reported as inhibition, at one concentration (the size of the read-out at that concentration, not a potency): 40%
Estimate against measurement, compound 4: 25 percentage points below, within the range that was stated.
By their numbers in this assay, from the lowest: compounds 1 and 2 (each within the scatter of the next); then compound 4; then compound 3.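

In this assay, an aromatic ring on this amide-type nitrogen is not needed for inhibition: the step to ethyl is a number 22 percentage points lower from compound 3 to compound 4 (beyond the scatter), and compound 4, which has no ring at this place, still gives 40%. The same ethyl group moves the number the other way when it replaces 2,5-dimethoxyphenyl, with a number 38 percentage points higher from compound 1 to compound 4 (beyond the scatter), so the outcome of exchanging an aryl group for ethyl depends on which aryl group leaves, and the loss seen in compound 1 is not shared by every group at this place. No measurement is at hand that would explain either step.

The compounds shown leave open how the number responds to other groups at this nitrogen, such as a longer chain like n-butyl, a chain ending in an amine, or an unsubstituted phenyl ring, any of which would show whether ethyl or 5-fluoro-2-methoxyphenyl lies nearer the better end of the range. They also leave open whether the order of compound 1, compound 4 and compound 3 would hold at other concentrations, since each number here comes from a single concentration and is not a potency.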